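Lengthening a chain: what happened once, and what is expected

The compounds below may be only part of what the source reports. "The series", "measured", "known", "first", "only" and "open" are said of these compounds alone.

Compound 1 `COC(=O)/C=C/c1ccc(C(C)C)cc1` and compound 3 `CCCCCOC(=O)/C=C/c1ccc(C(C)C)cc1` share a core; the difference between them is butyl in place of hydrogen on a saturated chain carbon bound to an oxygen next to a carbonyl group. In a functional assay on the whole organism for inhibition, with Brassica rapa subsp. chinensis as the target, with a stated time of 3 days, tested at 100 ppm (a higher number here means more inhibition of growth at the concentration tested, a lower number less inhibition of growth), compound 1 gives 21%, while compound 3 gives 0%. That step, a number 21 percentage points lower from compound 1 to compound 3 (beyond the scatter), shows how much growth inhibition was lost when the chain on the carbonyl side was lengthened.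

Compound 2 `CCCCCCCCNC(=O)/C=C/c1ccccc1` is built on a different core; the difference between the cores of compound 1 and compound 2 is not broken down here. In this assay compound 2 gives 42%, the highest of the three numbers. Compound 4 `CCCCCCCCCCCCNC(=O)/C=C/c1ccccc1` differs from compound 2 by butyl in place of hydrogen on a saturated chain carbon, eight bonds along the chain from an amide-type nitrogen. This is the same kind of change as from compound 1 to compound 3, though the place is not identical: there the butyl entered on a carbon bound to an oxygen next to a carbonyl group, here on a carbon eight bonds along the chain from an amide-type nitrogen. Because the earlier step was a number 21 percentage points lower from compound 1 to compound 3 (beyond the scatter), a loss of similar size is expected from compound 2 to compound 4, namely a number 17 percentage points lower from compound 2 to compound 4 (beyond the scatter). Compound 4 is therefore estimated at 25%, between 5% and 45%.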

Compound 4, percent growth inhibition at one concentration: 32%
For compound 4 the middle estimate is 7 percentage points below the measured one, and the stated range covers the measured number.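

In this assay, butyl in place of hydrogen on a saturated chain carbon, eight bonds along the chain from an amide-type nitrogen, gives a number 10 percentage points lower from compound 2 to compound 4 (within the scatter), so on this core the two chain lengths cannot be told apart. Set beside the earlier step on the other core, the change carries over without a difference that these measurements can resolve: the same change on two cores in this assay, a number 21 percentage points lower (beyond the scatter) from compound 1 to compound 3 and a number 10 percentage points lower (within the scatter) from compound 2 to compound 4, 11 percentage points apart, within the scatter of two such steps. For the compounds shown here, this does not show that the change has one fixed size: there are only two pairs, one step lies beyond the scatter and the other within it, and a real difference between the cores smaller than the scatter would go unseen.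

From the compounds shown here alone, it remains open whether a longer chain than that of compound 4 would keep the growth inhibition of compound 2 or lose it. It is also open how an amine or a carboxylic acid carried on the chain would compare with the plain chains shown here.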